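Pyrazin-2-yl in Place of Pyridin-3-yl: an Expectation

The source may report more compounds than this note shows. Statements on the series, on what has been measured and on what is new or still open speak of the compounds shown alone.

The measured compounds:
Compound 1 `Nc1ccccc1NC(=O)c1ccc(CSC(=S)N2CCN(c3ccc(Cl)cc3)CC2)cc1` gives 32.2% in a functional assay on A-375 cells (Homo sapiens) for antiproliferative activity, read by CCK-8 assay, with a stated time of 72 h, tested at 2 uM; on this read-out lower numbers stand for a weaker effect and higher numbers for a stronger effect at the one concentration tested.
Compound 2 `Nc1ccccc1NC(=O)c1ccc(CSC(=S)N2CCN(Cc3ccccc3)CC2)cc1` gives 10.6% in this assay.
Compound 3 `Nc1ccccc1NC(=O)c1ccc(CSC(=S)N2CCN(c3cccnc3)CC2)cc1` gives 40.5% in this assay.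

Compound 3 has the highest of the three numbers, but its gap to compound 1 lies within the scatter a number 8.3 percentage points higher from compound 1 to compound 3 (within the scatter), so the two cannot be ranked against each other. Only compound 2 stands clearly apart: a number 29.9 percentage points higher from compound 2 to compound 3 (beyond the scatter), and likewise a number 21.6 percentage points lower from compound 1 to compound 2 (beyond the scatter).

Compound 4 `Nc1ccccc1NC(=O)c1ccc(CSC(=S)N2CCN(c3cnccn3)CC2)cc1` is the compound not yet measured. It differs from compound 3 in one place: pyrazin-2-yl in place of pyridin-3-yl on an amine nitrogen in a ring.

Two measured steps change the same position. The step from compound 1 to compound 3 swapped one six-membered aromatic ring for another and stayed within the scatter a number 8.3 percentage points higher from compound 1 to compound 3 (within the scatter). The step from compound 2 to compound 3 replaced benzyl with pyridin-3-yl and was beyond the scatter, though modest a number 29.9 percentage points higher from compound 2 to compound 3 (beyond the scatter). The change to compound 4 resembles the first kind, a six-membered aromatic ring directly on the ring nitrogen exchanged for another, so the step is expected to stay within the scatter: a number 2.5 percentage points lower from compound 3 to compound 4 (within the scatter). Compound 4 is therefore estimated at 38% in this assay, with a range from 22% to 52%.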

Compound 4, a percentage reported as inhibition, at one concentration (the size of the read-out at that concentration, not a potency): 29.1%
Compound 4: middle estimate off by 8.9 percentage points, on the high side, and the stated range covers the measured number.
By their numbers in this assay, from the lowest: compound 2; then compounds 4, 1 and 3 (each within the scatter of the next, the first and the last beyond it).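

In this assay, exchanging one six-membered aromatic ring for another on this amine nitrogen does not always stay within the scatter: pyrazin-2-yl, with 2 hetero atoms, in place of pyridin-3-yl, with 1 hetero atom, gives a real step (a number 11.4 percentage points lower from compound 3 to compound 4 (beyond the scatter)). The exchange from 4-chlorophenyl to pyrazin-2-yl does stay within it (a number 3.1 percentage points lower from compound 1 to compound 4 (within the scatter)), so compound 1 lies within the scatter of both compound 3 and compound 4, even though those two are separated from each other. All three compounds with an aromatic ring directly on this nitrogen remain clear of the benzyl compound, and the new ring keeps that pattern with no exception among the four (a number 18.5 percentage points higher from compound 2 to compound 4 (beyond the scatter)).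

Nothing measured here explains the step between the two nitrogen-containing rings. Open questions are whether a plain phenyl, a pyridin-4-yl or a pyrimidin-5-yl ring on this nitrogen would land nearer compound 3 or compound 4, and whether a longer chain ending in a phenyl ring would fall even further than benzyl.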